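Inverting Three Ring Stereocentres in a Cytotoxic Core

This account rests on a few compounds, and the source may have more. Where it says the series, first, only, none or still open, it means among the compounds named here.

Measured compounds:
compound 1, `COC(=O)[C@@H]1C[C@@]2(CC=C(C)C)c3ccccc3N3C(=N)[C@H](Cc4ccccc4)N1[C@H]32`: 22100 nM
compound 2, `COC(=O)[C@@H]1C[C@@]2(CC=C(C)C)c3ccccc3N3C(=N)[C@H](c4ccccc4)N1[C@H]32`: > 100000 nM

Among the compounds with values here, compound 1 holds the only numerical value shown in a functional assay on A549 cells (Homo sapiens) for cytotoxicity, read by sulforhodamine B assay, with a stated time of 48 h; on this read-out lower numbers stand for stronger inhibition of growth and higher numbers for weaker inhibition of growth; in this assay compound 1 gives 22100 nM. Compound 2 reaches only a limit of the assay, (the limit of > 100000 nM in this assay, at which 1 of the 2 values shown sits), and in this assay compound 2 is reported as > 100000 nM. Within the data shown here, the one measured step, an at least 4.5-fold higher number from compound 1 to compound 2 (0.65 log units; beyond the scatter), concerns a change of substituent, not of stereochemistry.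

Compound 3, `COC(=O)[C@@H]1C[C@]2(CC=C(C)C)c3ccccc3N3C(=N)[C@@H](Cc4ccccc4)N1[C@@H]32`, has the same atoms and bonds as compound 1, and the change is the two compounds have the same atoms and bonds; at least one stereo element is drawn with a configuration in one of them and without one in the other: 3 of 5 stereo elements differ; a stereocentre at a saturated ring carbon is drawn S in compound 1 and R in compound 3; a stereocentre at a saturated ring carbon is drawn S in compound 1 and R in compound 3; a stereocentre at a saturated ring carbon is drawn R in compound 1 and S in compound 3. Among the measured compounds shown here, no measured step here touches a stereocentre, so the only measured step, from compound 1 to compound 2, bears on it indirectly at best: it shows that the core tolerates little alteration before the number runs into the limit. With no direct guide, the direction of the step from compound 1 to compound 3 in this assay is open; a loss is as plausible as a gain, and a limit is possible.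

Compound 3 is expected to give 35000 nM, within 8000 nM to 150000 nM, an expected step of a 1.6-fold higher number from compound 1 to compound 3 (0.20 log units; within the scatter).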

Compound 3, concentration for 50% growth inhibition: 12000 nM
Beside the measured number, compound 3's estimate is 2.9-fold (0.46 log units) above it; the measured number falls inside the stated range.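

Compound 3 has the same atoms and bonds as compound 1, so this pair isolates stereochemistry in a way the earlier step, a change of substituent, could not. In this assay the pair gives a 1.8-fold lower number from compound 1 to compound 3 (0.27 log units; within the scatter) and so, on this read-out, reversing three stereocentres at saturated ring carbons in one move leaves the two compounds indistinguishable, whereas phenyl in place of benzyl was a step beyond the scatter. This reading of the pair as a comparison of defined arrangements comes with one caution: the fact that one of compounds 1 and 3 is drawn with a defined configuration and the other without, at the place where they differ.

Because the three stereocentres differ together, the pair cannot show whether each one is individually unimportant or whether the effects of separate changes happen to offset one another, so inverting a single stereocentre remains an open test. Also open, on these data alone, is whether a carboxylic acid in place of the methyl ester, or a longer chain in place of the benzyl, would change the number, and whether it would do so equally in the arrangements of compound 1 and compound 3.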